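Swapping the Side Chain of a Benzyl Ester Analogue

The compounds below may be only part of what the source reports. "The series", "measured", "known", "first", "only" and "open" are said of these compounds alone.

Compound 1 `CSCC[C@H](NC(=O)CN(c1nc(Cl)nc2[nH]cnc12)C1CC1)C(=O)OCc1ccccc1` gives 17.6%.
Compound 2 `CSCC[C@H](NC(=O)CN(c1nc(Cl)nc2[nH]cnc12)C1CC1)C(=O)O` gives 4.14%.
Compound 3 `NC(=O)C[C@H](NC(=O)CN(c1nc(Cl)nc2[nH]cnc12)C1CC1)C(=O)O` gives 7.51%.

These three compounds were tested in a functional assay on the whole organism (Tail, strain ICR) with Mus musculus as the target, in the tail flick test, with a stated time of 150 min, at a dose of 25 umol/kg by the oral route; a higher number here means a stronger effect of the compound at the dose given, a lower number a weaker effect. Compound 1 stands highest of the three numbers; compound 3 lies nearest to it and compound 2 furthest, both beyond the scatter. The step from the benzyl ester to the free acid is a number 13.5 percentage points lower from compound 1 to compound 2 (beyond the scatter). The second step, exchanging one side chain for another on the free acid, is a number 3.4 percentage points higher from compound 2 to compound 3 (within the scatter), so that exchange did nothing beyond the scatter.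

Compound 4 `O=C(CN(c1nc(Cl)nc2[nH]cnc12)C1CC1)N[C@@H](CO)C(=O)OCc1ccccc1` has not yet been measured in this assay. It differs from compound 1 by hydroxy in place of (methylsulfanyl)methyl on a saturated chain carbon, two bonds along the chain from an amide-type nitrogen and a carbonyl carbon. Within the data shown here, the one measured step that bears on this change is the side-chain exchange from compound 2 to compound 3, which stayed within the scatter. The benzyl ester is retained in compound 4, so the larger drop seen on going to the free acid does not apply. On this basis a small step is expected, with no clear direction beyond the scatter, as a number 3.6 percentage points lower from compound 1 to compound 4 (within the scatter). Compound 4 is therefore estimated at 14%, within a range from 4% to 26%.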

Compound 4, a percentage reported as activity, at one dose (the size of the read-out at that dose, not a potency): 27.9%
Estimate against measurement, compound 4: 13.9 percentage points below, outside the stated range (above it).
By their numbers in this assay, from the lowest: compounds 2 and 3 (each within the scatter of the next); then compound 1; then compound 4.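

In this assay, with the benzyl ester kept, putting hydroxy in place of (methylsulfanyl)methyl on this saturated chain carbon gives a number 10.3 percentage points higher from compound 1 to compound 4 (beyond the scatter), so the side chain at this position can shift the read-out beyond the scatter. The earlier side-chain exchange, carbamoyl for (methylsulfanyl)methyl on the free acid, had not shown this, as it gave a number 3.4 percentage points higher from compound 2 to compound 3 (within the scatter), although that step differs from the new one in both the entering group and the acid or ester end. The new change replaces a group of 3 heavy atoms with no hydrogen-bond donor by a single oxygen that carries 1 hydrogen-bond donor, but no measurement here links either difference to the result, and nothing is available to explain it.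

The compounds shown do not tell whether hydroxy would give a similar step in the free acid series, where the benzyl ester is replaced by hydrogen. Nor do they tell whether an amine or methoxy group at this position, or a longer chain ending in hydroxy, would match compound 4 at this single dose and time.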